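Side group change from compound 3 to compound 4

A few compounds are considered here, and "the series" means these few. Any claim that something is new, unique, unknown or untested is made for them only; others in the source may bear on it.

Compound 1 `C=CCCCCCCCS(=O)(=O)/C=C/c1ccc(O)c(O)c1` gives 6900 nM in a functional assay, read by fluorescence and spectrophotometry, with a stated time of 1 h; a lower number here means that less compound is needed, a higher number that more compound is needed for the effect
Compound 2 `O=S(=O)(/C=C/c1ccc(O)c(O)c1)CCCCCCCCO` gives 6700 nM
Compound 3 `O=S(=O)(/C=C/c1ccc(O)c(O)c1)CC1CCCCO1` gives 10800 nM

In this assay compound 3 at 10800 nM stands within the scatter of both compound 1 and compound 2. The next compound is compound 4 `O=S(=O)(/C=C/c1ccc(O)c(O)c1)CCC1CCCC1` which has not yet been measured. The change from compound 3 is cyclopentylmethyl in place of oxan-2-yl on a saturated chain carbon bound to a sulfonyl sulfur and reads cyclopentylmethyl in place of oxan-2-yl on a saturated chain carbon bound to a sulfonyl sulfur.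

Going by the values given here, only one measured step compares two compounds that differ in one place: a 1.0-fold lower number from compound 1 to compound 2 (0.01 log units; within the scatter) and it lies within the scatter. That step concerns hydroxymethyl and vinyl, so it bears on the present change only loosely. Among the compounds with values here, no measured step covers the loss of oxan-2-yl or the arrival of cyclopentylmethyl. The expectation therefore rests on compound 3 at 10800 nM as the starting point, with no direction favoured and no shift beyond the scatter foreseen. The expected step is a 1.3-fold lower number from compound 3 to compound 4 (0.10 log units; within the scatter) and it is read as no real change. Compound 4 is estimated at 8500 nM as the middle value, with an expected range from 4000 nM to 18000 nM in this assay.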

Compound 4, half-maximal effective concentration: 6800 nM
Estimate against measurement, compound 4: 1.3-fold (0.10 log units) above; the measured number falls inside the stated range.
By their numbers in this assay, from the lowest: compounds 2, 4, 1 and 3 (each within the scatter of the next).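

In this assay, cyclopentylmethyl in place of oxan-2-yl on a saturated chain carbon bound to a sulfonyl sulfur gives a 1.6-fold lower number from compound 3 to compound 4 (0.20 log units; within the scatter), so at this position the loss of the ring oxygen and its hydrogen-bond acceptor, together with the move from a six-membered to a five-membered ring, is not resolved from the scatter. The carbon-only ring also reads level with the open chains, with a 1.0-fold higher number from compound 2 to compound 4 (0.01 log units; within the scatter) for cyclopentyl in place of 6-hydroxyhexyl and a 1.0-fold lower number from compound 1 to compound 4 (0.01 log units; within the scatter) for cyclopentyl in place of hept-6-en-1-yl, and so across these four compounds neither ring against open chain nor oxygen-bearing against carbon-only group separates in this read-out. No supporting measurement bears on why these groups read alike.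

Still open, going by these compounds, is whether this position responds to any group at all, for instance a carboxylic acid or an amine at the end of the chain, or a phenyl ring in place of cyclopentyl. All four compounds also carry the same shared core, so whether the same flat reading holds on a different core remains unsettled.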